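Hydroxyphenyl Hydrazone Variant of a Weakly Cytotoxic Series

This account rests on a few compounds, and the source may have more. Where it says the series, first, only, none or still open, it means among the compounds named here.

Measured compounds:
compound 1, `CN(C)CCn1cnnc1-c1cc(Oc2ccc(NC(=O)N/N=C/c3c(Cl)cccc3Cl)cc2F)ccn1`, > 100000 nM
compound 2, `COc1cc(/C=N/NC(=O)Nc2ccc(Oc3ccnc(-c4nncn4CCN(C)C)c3)c(F)c2)cc(OC)c1OC`, 22500 nM
compound 3, `CN(C)CCn1cnnc1-c1cc(Oc2ccc(NC(=O)N/N=C/c3cc(Br)c(O)c(Br)c3)cc2F)ccn1`, > 100000 nM

In a functional assay on U-87MG ATCC cells (Homo sapiens) for cytotoxicity, read by MTT assay, with a stated time of 72 h (on this read-out higher numbers stand for weaker inhibition and lower numbers for stronger inhibition), compound 1 gives > 100000 nM, which is a limit of the assay and not a number. Compound 3 likewise gives > 100000 nM in this assay, again a limit. For the measured compounds named here, compound 2 is the only one with a measured number, 22500 nM, so compound 1 stands at the weak end among the values shown, as the limit of > 100000 nM in this assay, at which 2 of the 3 values shown sit, records.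

Compound 4 is `CN(C)CCn1cnnc1-c1cc(Oc2ccc(NC(=O)N/N=C/c3ccc(O)cc3)cc2F)ccn1`. Its change from compound 1 is 4-hydroxyphenyl in place of 2,6-dichlorophenyl on a carbon with a double bond to nitrogen. Of the measured steps, an at least 4.4-fold lower number from compound 1 to compound 2 (0.64 log units; beyond the scatter) shows that exchanging the 2,6-dichlorophenyl can bring the number down, while a step that the two limits leave unreadable from compound 1 to compound 3, a hydroxyphenyl bearing two bromines, left the value at the limit. Compound 4 is therefore expected to stay weak, with a step from compound 1 of an at least 1.6-fold lower number from compound 1 to compound 4 (0.22 log units; that floor lies within the scatter) at most, and an estimate of 60000 nM in this assay, within 15000 nM to 200000 nM.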

Compound 4, half-maximal inhibitory concentration: 7750 nM
Estimate against measurement, compound 4: 7.7-fold (0.89 log units) above, and the stated range ends above it.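

For the compounds shown here, with 4-hydroxyphenyl on the carbon with a double bond to nitrogen, the series reaches its strongest value in this assay, with an at least 12-fold lower number from compound 1 to compound 4 (1.11 log units; beyond the scatter) and, against the only other measured number, a 2.9-fold lower number from compound 2 to compound 4 (0.46 log units; beyond the scatter). A hydroxyphenyl alone does not bring this about, as the exchange of 3,5-dibromo-4-hydroxyphenyl for 4-hydroxyphenyl gives an at least 12-fold lower number from compound 3 to compound 4 (1.11 log units; beyond the scatter). Compound 1 and compound 3 each remain at a limit of the assay and not at a number: the limit of > 100000 nM in this assay, at which 2 of the 4 values shown sit.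

The compounds shown leave open whether the hydroxyl itself matters at this place, which an unsubstituted phenyl or an aminophenyl in place of the 4-hydroxyphenyl would test. They also leave open whether a single bromine on the hydroxyphenyl would already return the number to the limit.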